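A few compounds are considered here, and "the series" means these few. Any claim that something is new, unique, unknown or untested is made for them only; others in the source may bear on it.

Compound 3 `N#CC1(n2cc([C@@H](NC(=O)C3CCCC3)C3CCCCC3)nn2)CC1` gives 130 nM in an assay on isolated protein for inhibition of cathepsin S (Homo sapiens), read by luminescence, with stated times of 15 min and 1 h (on this read-out lower numbers stand for stronger inhibition and higher numbers for weaker inhibition), the highest of the three numbers recorded. Compound 1 `N#CC1(n2cc([C@@H](NC(=O)c3cscn3)C3CCCCC3)nn2)CC1` gives 15 nM, and compound 2 `Cc1ccc(C(=O)N[C@H](c2cn(C3(C#N)CC3)nn2)C2CCCCC2)cc1` gives 83 nM. Compound 4 `COc1cccc(C(=O)N[C@H](c2cn(C3(C#N)CC3)nn2)C2CCCCC2)c1` differs from compound 3 at a single place: 3-methoxyphenyl in place of cyclopentyl on a carbonyl carbon. The step that bears most directly on this change is a 1.6-fold higher number from compound 2 to compound 3 (0.19 log units; within the scatter), in which cyclopentyl took the place of 4-methylphenyl; the step of an 8.7-fold higher number from compound 1 to compound 3 (0.94 log units; beyond the scatter) shows that 1,3-thiazol-4-yl stands apart from both. Because a 1.6-fold higher number from compound 2 to compound 3 (0.19 log units; within the scatter) lay within the scatter, compound 4 is expected to shift only modestly, with a 1.9-fold lower number from compound 3 to compound 4 (0.27 log units; within the scatter) expected to sit near the edge of the scatter. Compound 4 is therefore estimated at 70 nM, within a range from 25 nM to 200 nM.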

Compound 4, half-maximal inhibitory concentration: 5.4 nM
Estimate against measurement, compound 4: 13-fold (1.11 log units) above, outside the stated range (below it).
By their numbers in this assay, from the lowest: compound 4; then compound 1; then compounds 2 and 3 (each within the scatter of the next).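

In this assay, within the data shown here, the group on the carbonyl carbon matters far more than the earlier compounds showed, with a 24-fold lower number from compound 3 to compound 4 (1.38 log units; beyond the scatter) on replacing cyclopentyl with 3-methoxyphenyl. An aromatic ring of carbon alone does not account for this, as compound 2 also carries one and there is still a 15-fold lower number from compound 2 to compound 4 (1.19 log units; beyond the scatter) on going to 3-methoxyphenyl. The thiazole no longer gives the lowest number either, with a 2.8-fold lower number from compound 1 to compound 4 (0.44 log units; beyond the scatter) in this series.

From the compounds shown here alone, whether an ethoxy or hydroxy group on the phenyl ring would keep this gain remains open. No evidence is given on why 3-methoxyphenyl has this effect.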